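Difluoromethyl on the pyrazole nitrogen of compound 2

The source may report more compounds than this note shows. Statements on the series, on what has been measured and on what is new or still open speak of the compounds shown alone.

The pair studied here shares a core built around compound 2, `Cc1cc(-c2c(C)n[nH]c2C)ccc1-c1nnc(N(C)Cc2ccc3nccn3c2)o1`, and compound 1, `CN(Cc1ccc2nccn2c1)c1nnc(-c2ccc(-c3ccccc3F)cc2)o1`. In a physicochemical assay for lipophilicity, at pH 7.4 (on this read-out lower numbers stand for lower lipophilicity and higher numbers for higher lipophilicity), compound 1 gives 4.4. In this assay compound 2 gives 3.8, the lowest of the two numbers, with compound 1 standing higher by a margin beyond the usual scatter. Among the measured compounds shown here, no step between two measured compounds that differ in a single place is available, so the effect of a small change on the read-out cannot be read off directly from these two.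

Compound 3, `Cc1cc(-c2c(C)nn(C(F)F)c2C)ccc1-c1nnc(N(C)Cc2ccc3nccn3c2)o1`, has not yet been measured. It differs from compound 2 in one place: difluoromethyl in place of hydrogen on an aromatic nitrogen, in words, difluoromethyl in place of hydrogen on an aromatic nitrogen. For the measured compounds named here, no measured pair carries this change, so the expectation rests on the structural change alone. Compound 3 is expected to lie above compound 2, by a step of a number 0.70 log units higher from compound 2 to compound 3 (beyond the scatter), somewhat beyond the scatter. The estimate for compound 3 is 4.5, within a range from 4 to 5.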

Compound 3, distribution coefficient: 4.1
Compound 3: the middle estimate sits 0.40 log units above what was measured; measured number inside the range.
By their numbers in this assay, from the lowest: compounds 2, 3 and 1 (each within the scatter of the next, the first and the last beyond it).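

In this assay, among the compounds shown here, the one comparison that differs in a single place gives a number 0.30 log units higher from compound 2 to compound 3 (within the scatter), so the measurement does not separate the hydrogen from the difluoromethyl on this aromatic nitrogen. For the compounds shown here, this pair is the first direct reading at this position, and it shows that the 3,5-dimethyl-1H-pyrazol-4-yl group can become the 1-(difluoromethyl)-3,5-dimethyl-1H-pyrazol-4-yl group with no difference beyond the usual scatter of this read-out. No measurement bears on why the step has this size.

The compounds shown leave open whether another group on this aromatic nitrogen, such as trifluoromethyl, a longer alkyl chain, an amine or a carboxylic acid, would give a step beyond the scatter. Going by these compounds alone, they also leave open whether difluoromethyl in place of hydrogen would give a similar step on a ring without the methyl groups that this one carries, since this single pair is the only reading of the change.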